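Hydrazone aryl variation and cytotoxicity across the shared core

The source may hold more compounds than are shown below. What is called first, only, known or untested is meant among the compounds shown, and "the series" means these compounds.

Measured so far:
compound 1 `CN(C)CCn1cnnc1-c1cc(Oc2ccc(NC(=O)N/N=C/c3ccc(Cl)cc3)cc2F)ccn1` gives 1870 nM
compound 2 `CN(C)CCn1cnnc1-c1cc(Oc2ccc(NC(=O)N/N=C/c3cc(C(C)(C)C)cc(C(C)(C)C)c3O)cc2F)ccn1` gives 2350 nM
compound 3 `CN(C)CCn1cnnc1-c1cc(Oc2ccc(NC(=O)N/N=C/c3ccc(O)c(Br)c3)cc2F)ccn1` gives 5560 nM

In an ADME assay on WI-38 cells (Homo sapiens) for cytotoxicity, read by MTT assay, with a stated time of 72 h (a higher number here means a weaker inhibitor, a lower number a stronger inhibitor), compound 3 stands highest of the three numbers, beyond the scatter of both compound 2 and compound 1. Compound 4 `CN(C)CCn1cnnc1-c1cc(Oc2ccc(NC(=O)N/N=C/c3ccc(F)cc3F)cc2F)ccn1` is not yet measured; it differs from compound 3 by 2,4-difluorophenyl in place of 3-bromo-4-hydroxyphenyl on a carbon with a double bond to nitrogen. Among the measured compounds shown here, the one measured step at this position, a 3.0-fold higher number from compound 1 to compound 3 (0.47 log units; beyond the scatter), is modest. Compound 4, with its 2,4-difluorophenyl, resembles the 4-chlorophenyl of compound 1 more than the 3-bromo-4-hydroxyphenyl of compound 3, so a step of roughly the same size in the opposite direction is expected, a 2.5-fold lower number from compound 3 to compound 4 (0.40 log units; beyond the scatter). For compound 4 the estimate is 2200 nM, with a range from 1000 nM to 5000 nM.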

Compound 4, half-maximal inhibitory concentration: 5030 nM
Compound 4: the middle estimate sits 2.3-fold (0.36 log units) below what was measured; measured number above the stated range.
By their numbers in this assay, from the lowest: compounds 1 and 2 (each within the scatter of the next); then compounds 4 and 3 (each within the scatter of the next).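

In this assay, the step of a 1.1-fold lower number from compound 3 to compound 4 (0.04 log units; within the scatter) puts 2,4-difluorophenyl level with 3-bromo-4-hydroxyphenyl on this carbon, even though 2,4-difluorophenyl has neither the hydrogen-bond donor nor the acceptor counted on 3-bromo-4-hydroxyphenyl. Carrying only halogen on the aryl ring does not fix the number either, given a 2.7-fold higher number from compound 1 to compound 4 (0.43 log units; beyond the scatter) as 2,4-difluorophenyl replaces 4-chlorophenyl. Still open, going by these compounds, is whether an aryl ring bearing an amine or a carboxylic acid would shift the number from these values. No measurement on hand accounts for either step.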